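A few compounds are considered here, and "the series" means these few. Any claim that something is new, unique, unknown or untested is made for them only; others in the source may bear on it.

Measured so far in an ADME assay on SK-OV-3 cells (Homo sapiens) for cytotoxicity, read by sulforhodamine B assay, with a stated time of 48 h, tested at 10 uM; on this read-out higher numbers stand for more inhibition at the one concentration tested (going by the name of the read-out) and lower numbers for less inhibition:
compound 1, `CCCCCCc1cn(C(c2ccccc2)c2cc3cc(Br)ccc3nc2OC)nn1`: 7.17%
compound 2, `COc1nc2ccc(Br)cc2cc1C(c1ccccc1)n1cc(CCCO)nn1`: 13.8%
compound 3, `COc1nc2ccc(Br)cc2cc1C(c1ccccc1)n1cc(-c2ccc(OC(F)(F)F)cc2)nn1`: 14.8%

Compound 3 carries the highest of the three numbers, but the gap a number 1 percentage points higher from compound 2 to compound 3 (within the scatter) and the gap a number 7.6 percentage points higher from compound 1 to compound 3 (within the scatter) both sit within the scatter, so the three compounds cannot be told apart on these data. The remaining step, a number 6.6 percentage points higher from compound 1 to compound 2 (within the scatter), is also within the scatter.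

Compound 4, `COc1nc2ccc(Br)cc2cc1C(c1ccccc1)n1cc(-c2ccccc2C(F)(F)F)nn1`, is still to be measured. Its difference from compound 3 is 2-(trifluoromethyl)phenyl in place of 4-(trifluoromethoxy)phenyl on an aromatic carbon. Among the measured compounds shown here, the measured steps that touch the same position on the shared core are a number 7.6 percentage points higher from compound 1 to compound 3 (within the scatter) and a number 1 percentage points higher from compound 2 to compound 3 (within the scatter); neither moved the read-out beyond the scatter, and no measured pair sets the entering group against the leaving group. Nothing here supports a step beyond the scatter in either direction, so the expected outcome is a number close to that of compound 3.

For compound 4 in this assay the estimate is 13%, with a range from 2% to 26%. This estimate is expected to amount to a number 1.8 percentage points lower from compound 3 to compound 4 (within the scatter).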

Compound 4, a percentage reported as inhibition, at one concentration (the size of the read-out at that concentration, not a potency): 9.55%
Estimate against measurement, compound 4: 3.5 percentage points above; the range from low to high includes it.
By their numbers in this assay, from the lowest: compounds 1, 4, 2 and 3 (each within the scatter of the next).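

In this assay, the aromatic carbon of the five-membered ring now carries a fourth group, 2-(trifluoromethyl)phenyl, and each comparison gives a step within the scatter: a number 5.3 percentage points lower from compound 3 to compound 4 (within the scatter) and a number 4.3 percentage points lower from compound 2 to compound 4 (within the scatter) and a number 2.4 percentage points higher from compound 1 to compound 4 (within the scatter). Replacing 4-(trifluoromethoxy)phenyl with 2-(trifluoromethyl)phenyl therefore gives no readable change, and the two substituted phenyl groups, hexyl and 3-hydroxypropyl cannot be told apart at this position. No supporting measurement bears on this result.

On these data alone, whether any group at this position can move the read-out beyond the scatter remains open. A phenyl group carrying an amine or a carboxylic acid, or a longer chain ending in an amine, is not among the compounds shown, so these groups remain untested here.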